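The source may report more compounds than this note shows. Statements on the series, on what has been measured and on what is new or still open speak of the compounds shown alone.

Measured compounds in an assay on isolated protein for inhibition of biotin--protein ligase (Homo sapiens), read by scintillation counting, with a stated time of 10 min; on this read-out lower numbers stand for stronger inhibition and higher numbers for weaker inhibition:
Compound 1 `O=C1N[C@H]2[C@H](CS[C@H]2CCCCCc2cn(Cc3ccccc3O)nn2)N1` gives > 16000 nM, which is a limit of the assay, not a number.
Compound 2 `O=C1N[C@H]2[C@H](CS[C@H]2CCCCCc2cn(Cc3cccc(O)c3)nn2)N1` gives > 16000 nM, also a limit.
Compound 3 `COc1cccc(Cn2cc(CCCCC[C@@H]3SC[C@@H]4NC(=O)N[C@@H]43)nn2)c1` gives > 16000 nM, again a limit.

Compound 3 therefore stands where every measured compound in the series stands, at the shared limit: the limit of > 16000 nM in this assay, at which 3 of the 3 values shown sit. Since none of the three values is a number, the three single-point changes among them have no readable size: a step that the two limits leave unreadable from compound 1 to compound 2, a step that the two limits leave unreadable from compound 1 to compound 3 and a step that the two limits leave unreadable from compound 2 to compound 3.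

Compound 4 `Nc1cccc(Cn2cc(CCCCC[C@@H]3SC[C@@H]4NC(=O)N[C@@H]43)nn2)c1` differs from compound 3 in one place: amino in place of methoxy on an aromatic carbon. For the measured compounds named here, the only measured steps that bear on this change are the three above, and each is unreadable because of the limit of > 16000 nM in this assay, at which 3 of the 3 values shown sit; the benzyl substituent has been varied without any compound reaching a number in this assay. No size in either direction can be read off for the change to compound 4, and the working expectation is that compound 4 also remains at the limit. Compound 4 is estimated at 25000 nM, with a range from 8000 nM to 80000 nM, the expected step from compound 3 being a step that the limit leaves unreadable from compound 3 to compound 4.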

Compound 4, inhibition constant: > 16000 nM
Compound 4 gave a limit, no number; the forecaster's own chance of this, stated with the estimate: 80%; the middle value lies beyond the limit too.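

Compound 4 gives > 16000 nM which is a limit and not a number. No step among compound 1, compound 2, compound 3 and compound 4 can be read, because all remain at the shared limit: the limit of > 16000 nM in this assay, at which 4 of the 4 values shown sit.

In this assay the compounds shown leave open whether any benzyl substituent on the shared core gives a number.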